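Aryl in place of pentyl on the sulfonyl of a hydrazide

The source may hold more compounds than are shown below. What is called first, only, known or untested is meant among the compounds shown, and "the series" means these compounds.

Three close relatives of one scaffold have been examined in an assay on HEK293 cells for displacement of a labelled ligand from Type-2 angiotensin II receptor (Homo sapiens), tested at 10 uM; a higher number here means a stronger effect of the compound at the concentration tested, a lower number a weaker effect. Compound 1 `CC[C@H](C)[C@H](NC(=O)c1cccc(Cn2ccnc2)c1)C(=O)NNS(=O)(=O)c1ccccc1` gives 18% in this assay. Compound 2 `CC[C@H](C)[C@H](NC(=O)c1cccc(Cn2ccnc2)c1)C(=O)NNS(=O)(=O)c1c(C)cc(C)cc1C`, which carries 2,4,6-trimethylphenyl in place of phenyl on the sulfonyl sulfur, gives 27%; the step of a number 9 percentage points higher from compound 1 to compound 2 (within the scatter) lies within the scatter, so the two aryl sulfonyl compounds are best regarded as alike. Compound 3 `CCCCCS(=O)(=O)NNC(=O)[C@@H](NC(=O)c1cccc(Cn2ccnc2)c1)[C@@H](C)CC`, with a pentyl chain on the sulfonyl sulfur, gives "not determined" (no result reported) in this assay, so it has no number here and cannot be placed against the other two.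

Compound 4 `CC[C@H](C)[C@H](NC(=O)c1cccc(Cn2ccnc2)c1)C(=O)NNS(=O)(=O)c1ccc(OC)cc1` is the next member. Against compound 3 the difference is 4-methoxyphenyl in place of pentyl on a sulfonyl sulfur. Among the measured compounds shown here, no measured step covers the exchange of a chain for an aryl group on the sulfonyl sulfur. For the measured compounds named here, the only measured step, from compound 1 to compound 2, swaps one aryl group for another and stays within the scatter, which suggests that the aryl sulfonyl end tolerates variation without large effects. Compound 4 resembles compounds 1 and 2 in carrying an aryl sulfonyl group, so its reading is expected to fall near theirs. For compound 4 the estimate in this assay is 22%, with a range from 5% to 40%.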

Compound 4, a percentage reported as inhibition, at one concentration (the size of the read-out at that concentration, not a potency): 20%
The estimate for compound 4 lay 2 percentage points above the measured number; low and high end bracket the measured number.
By their numbers in this assay, from the lowest: compounds 1, 4 and 2 (each within the scatter of the next).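

Compound 4 adds a third aryl group on the sulfonyl sulfur, and this time the change is a single added group on the ring of compound 1: in this assay, methoxy in place of hydrogen on an aromatic carbon gives a number 2 percentage points higher from compound 1 to compound 4 (within the scatter). Exchanging the 2,4,6-trimethylphenyl group for 4-methoxyphenyl gives a number 7 percentage points lower from compound 2 to compound 4 (within the scatter), so phenyl, 2,4,6-trimethylphenyl and 4-methoxyphenyl all read alike at this position, whether the ring carries methyl groups, a methoxy group or neither. The data offer no explanation for this likeness, and the exchange of pentyl for 4-methoxyphenyl cannot be read, as compound 3 has no number.

From the compounds shown here alone, whether any group on the sulfonyl sulfur can move the reading beyond the scatter remains open, for example a phenyl ring carrying a carboxylic acid or an amine. Also open, going by these compounds, is how an open chain compares with an aryl group at this position, whether that chain is pentyl or a shorter one such as methyl.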